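Aryl chloro to fluoro swap in a sulfonamide amide series

This account rests on a few compounds, and the source may have more. Where it says the series, first, only, none or still open, it means among the compounds named here.

Measured compounds: compound 1 `CCCS(=O)(=O)Nc1ccc(Cl)c(C(=O)Nc2cnc3[nH]nc(OC)c3c2)c1F`, 2 ug/mL; compound 2 `CC(C)CS(=O)(=O)Nc1ccc(F)c(C(=O)Nc2cnc3[nH]nc(C4CC4)c3c2)c1Cl`, < 1 ug/mL; compound 3 `O=C(Nc1cnc2[nH]nc(C3CC3)c2c1)c1c(F)ccc(NS(=O)(=O)CCCF)c1Cl`, 265 ug/mL.

In a physicochemical assay for solubility, at pH 7.4 (a higher number here means a more soluble compound, a lower number a less soluble compound), compound 1 gives the lowest of the two numbers shown; compound 3 gives 265 ug/mL, a far higher number. For compound 2 the value is a limit of the assay, (the limit of < 1 ug/mL in this assay, at which 1 of the 3 values shown sits). Within the data shown here, the only measured step, an at least 260-fold higher number from compound 2 to compound 3 (2.42 log units; beyond the scatter), concerns the sulfonyl chain and not the aromatic halide.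

Compound 4 `CCCS(=O)(=O)Nc1ccc(F)c(C(=O)Nc2cnc3[nH]nc(OC)c3c2)c1F` differs from compound 1 by fluoro in place of chloro on an aromatic carbon. Among the measured compounds shown here, no measured step covers this change, so the expectation rests on compound 1 alone. The number for compound 4 is expected to stay close to that of compound 1, a 2.0-fold higher number from compound 1 to compound 4 (0.30 log units; within the scatter), with an estimate of 4 ug/mL in a range of 1 ug/mL to 15 ug/mL.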

Compound 4, solubility: 9 ug/mL
Compound 4: middle estimate off by 2.3-fold (0.35 log units), on the low side; the measured number falls inside the stated range.
By their numbers in this assay, from the lowest: compound 1; then compound 4; then compound 3. At a limit, below all of these: compound 2.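

In this assay, the aromatic carbon ortho to a large group and para to a (propylsulfonyl)amino group responds to the halide: fluoro in place of chloro gives a 4.5-fold higher number from compound 1 to compound 4 (0.65 log units; beyond the scatter). Among these compounds, the earlier compounds offered no step at this position, as their only step concerns the sulfonyl chain. Nothing available here accounts for this change.

As far as these compounds go, whether the swap gives a step of similar size with a longer chain on the sulfonyl stays open. So does the outcome of an amine at this position.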